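The source may report more compounds than this note shows. Statements on the series, on what has been measured and on what is new or still open speak of the compounds shown alone.

Measured compounds in an ADME assay on MT4 cells (Homo sapiens) for cytotoxicity; a lower number here means that less compound is tolerated, a higher number that more compound is tolerated:

Compound 1, `COC(=O)N[C@H](C(=O)NN(CCC[C@@](O)(Cc1ccccc1)C(=O)N[C@H]1c2ccccc2C[C@H]1O)Cc1ccc(F)cc1)C(C)(C)C`. In this assay compound 1 gives > 10000 nM, a limit of the assay rather than a number.
Compound 2, `COC(=O)N[C@H](C(=O)NN(CCC[C@@](O)(Cc1ccccc1)C(=O)N[C@H]1c2ccccc2C[C@H]1O)Cc1ccc(-c2ccccn2)cc1)C(C)(C)C`. In this assay compound 2 gives > 10000 nM, again only a limit.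
Compound 3, `COC(=O)N[C@H](C(=O)NN(CCC[C@@](O)(Cc1ccccc1)C(=O)N[C@H]1c2ccccc2C[C@H]1O)Cc1ccc(-c2cncnc2)cc1)C(C)(C)C`. In this assay compound 3 gives > 10000 nM, also a limit.

Compound 2 therefore stands where every other member of the series stands: at the limit, with nothing separating it from the rest, since (the limit of > 10000 nM in this assay, at which 3 of the 3 values shown sit). The three measured steps, a step that the two limits leave unreadable from compound 1 to compound 2, a step that the two limits leave unreadable from compound 1 to compound 3 and a step that the two limits leave unreadable from compound 2 to compound 3, are all unreadable for the same reason; no size and no direction can be taken from them.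

Compound 4, `COC(=O)N[C@H](C(=O)NN(CCC[C@@](O)(Cc1ccccc1)C(=O)N[C@H]1c2ccccc2C[C@H]1O)Cc1ccc(-c2cccnc2)cc1)C(C)(C)C`, differs from compound 2 by pyridin-3-yl in place of pyridin-2-yl on an aromatic carbon. Within the data shown here, the step that comes closest, swapping one aromatic group for another on the same carbon, is the one from compound 2 to compound 3, and it too is hidden by the limit. Nothing in the series shows a change at this position reaching a readable value, so the step from compound 2 to compound 4 is expected to be a step that the limit leaves unreadable from compound 2 to compound 4, none beyond the scatter. Compound 4 is expected to give 20000 nM in this assay, between 10000 nM and 60000 nM, most likely reported again only as a limit.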

Compound 4, half-maximal cytotoxic concentration: > 10000 nM
Compound 4: no number, only a limit (the forecaster's own chance of this, stated with the estimate: 90%); the middle value lies beyond the limit too.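

In this assay, among these compounds, no step from compound 4 to compound 1, compound 2 or compound 3 can be read, and each value is a limit rather than a number: the limit of > 10000 nM in this assay, at which 4 of the 4 values shown sit. The compounds shown leave open how far any of them lies beyond that limit, and whether changing the aromatic group alters the read-out at all.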